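This account rests on a few compounds, and the source may have more. Where it says the series, first, only, none or still open, it means among the compounds named here.

In an ADME assay on J774 cells (Mus musculus) for antiproliferative activity, with a stated time of 72 h (a lower number here means that less compound is needed, a higher number that more compound is needed for the effect), two compounds that share one core have been measured. Compound 1 `CCc1c(C)[nH]c2cc(OCCOc3ccccc3)c(Cl)cc2c1=O` carries a chloro group and reads > 28000 nM as a limit of the assay, not a number. Compound 2 `CCc1c(C)[nH]c2cc(OCCOc3ccccc3)c(OC)cc2c1=O` carries methoxy in that place and reads > 29000 nM as a limit too. For the measured compounds named here, compound 2 therefore stands only at a limit, and the one further value available is also a limit. Compound 3 `CCc1c(C)[nH]c2cc(OCCOc3ccccc3)c(Br)cc2c1=O` has bromo in place of methoxy on an aromatic carbon, ortho to a large group. Going by the values given here, the one measured step that bears on this change is a step that the two limits leave unreadable from compound 1 to compound 2 and it has no readable size. It supports no expectation of a real change, so no step beyond the scatter is expected in this assay and compound 3 should sit near those limits. The expected size of the step is estimated as a number no higher from compound 2 to compound 3 (the limit leaves the size open) on this reasoning. Compound 3 is estimated at 29000 nM (14000 nM to 50000 nM).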

Compound 3, half-maximal effective concentration: > 25000 nM
Compound 3: a limit, no number; the forecaster's own chance of this, stated with the estimate: 85%; the middle value lies beyond the limit too.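

In this assay, for the compounds shown here, compound 3 gives only a limit, as do compound 1 and compound 2, so no step between these three compounds can be read. The compounds shown leave open whether chloro, methoxy and bromo at this place differ at all in their effect.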